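Compound 3 to compound 4: a new group on nitrogen

A few compounds are considered here, and "the series" means these few. Any claim that something is new, unique, unknown or untested is made for them only; others in the source may bear on it.

In a functional assay on DU-145 cells (Homo sapiens) for inhibition, read by trypan blue exclusion, with a stated time of 72 h (on this read-out lower numbers stand for stronger inhibition and higher numbers for weaker inhibition), compound 1 (`Cn1c(=O)c(S(=O)(=O)Cc2ccc(F)cc2)cc2cnc(Nc3ccc4[nH]ccc4c3)nc21`) gives 30000 nM. Compound 2 (`COc1ccc(Nc2ncc3cc(S(=O)(=O)c4ccc(Cl)cc4)c(=O)n(C)c3n2)cc1`) gives 30000 nM. Compound 3 (`Cn1c(=O)c(S(=O)(=O)c2ccc(F)cc2F)cc2cnc(Nc3ccc4c(c3)CC(=O)N4)nc21`) gives 100000 nM, the highest of the three numbers and beyond the scatter from both others. The next compound to be read is compound 4 (`Cn1c(=O)c(S(=O)(=O)c2ccc(F)cc2F)cc2cnc(Nc3ccc4cc[nH]c4c3)nc21`), which differs from compound 3 in one place: a group of 9 heavy atoms (8 carbon, 1 nitrogen; one five-membered aromatic ring with 1 hetero atom, one six-membered aromatic ring of carbon only) in place of a group of 10 heavy atoms (8 carbon, 1 nitrogen, 1 oxygen; one five-membered non-aromatic ring with 1 hetero atom, one six-membered aromatic ring of carbon only), on a nitrogen on an aromatic ring. The entering group is 1H-indol-6-yl. Among the compounds with values here, no measured pair differs in only one place, so any expectation rests on thin evidence. Compound 1 also carries a group with a five-membered aromatic ring on a nitrogen on an aromatic ring, and it gives 30000 nM, although it differs from compound 4 elsewhere as well. On that basis, a modest move towards stronger inhibition is expected, and the estimated change is a 2.5-fold lower number from compound 3 to compound 4 (0.40 log units; beyond the scatter). Compound 4 is estimated at 40000 nM, with an expected range from 10000 nM to 100000 nM.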

Compound 4, half-maximal inhibitory concentration: 5000 nM
Compound 4: the middle estimate sits 8.0-fold (0.90 log units) above what was measured, and the stated range ends above it.
By their numbers in this assay, from the lowest: compound 4; then compounds 1 and 2 (each within the scatter of the next); then compound 3.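

In this assay, within the data shown here, replacing the group with the five-membered non-aromatic ring by 1H-indol-6-yl, on a nitrogen on an aromatic ring, gives a 20-fold lower number from compound 3 to compound 4 (1.30 log units; beyond the scatter) and is the first single-place comparison. This position therefore responds strongly to the attached group, even though the two groups differ by only one heavy atom, the oxygen, and the rest of the molecule stays the same. Nothing available explains the size of this step.

Among these compounds, compound 1 and compound 2 differ from compound 4 in more than one place, so a single step remains the only reading of this position. From the compounds shown here alone, it is also open how this position would read with a phenyl group carrying an amine or a carboxylic acid, with the rest of compound 4 kept.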